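The source may report more compounds than this note shows. Statements on the series, on what has been measured and on what is new or still open speak of the compounds shown alone.

In a functional assay on PC-3 cells (Homo sapiens) for cytotoxicity, read by WST assay, with a stated time of 72 h (a higher number here means a weaker inhibitor, a lower number a stronger inhibitor), compound 1 `O=C1Nc2c(ccc(F)c2F)C1(c1ccccc1)c1ccc(O)cc1` gives 8.9 nM and compound 2 `CCOc1ccc(C2(c3ccc(O)cc3)C(=O)Nc3c2ccc(F)c3F)cc1` gives 24 nM. Compound 3 `O=C1Nc2c(ccc(F)c2F)C1(c1ccc(O)cc1)c1cccnc1` reads > 1000 nM in this assay, which is a limit of the assay and not a number. Compound 4 `CCCC1(c2ccc(O)cc2)C(=O)Nc2c1ccc(F)c2F` carries propyl in place of pyridin-3-yl on a saturated ring carbon. Within the data shown here, two measured steps concern the group at this carbon. Putting pyridin-3-yl in place of phenyl gave an at least 110-fold higher number from compound 1 to compound 3 (2.05 log units; beyond the scatter), and putting it in place of 4-ethoxyphenyl gave an at least 41-fold higher number from compound 2 to compound 3 (1.61 log units; beyond the scatter); both are large. The ethoxy step gave only a 2.7-fold higher number from compound 1 to compound 2 (0.43 log units; beyond the scatter), a modest change. Among these three compounds, the high reading comes only with pyridin-3-yl, so its removal is expected to bring the number down. However, no measured compound has an open chain at this carbon, so the expectation remains loose. The expected change is an at least 8.3-fold lower number from compound 3 to compound 4 (0.92 log units; beyond the scatter), a large step towards a stronger inhibitor. The estimated value for compound 4 is 120 nM, with an expected range from 20 nM to 800 nM.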

Compound 4, half-maximal inhibitory concentration: > 1000 nM
Compound 4: no number, only a limit; the forecaster's own chance of this, stated with the estimate: 20%; middle value at least 8.3-fold (0.92 log units) from the limit.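

Propyl at this saturated ring carbon gives an at least 110-fold higher number from compound 1 to compound 4 (2.05 log units; beyond the scatter) when set against phenyl and an at least 41-fold higher number from compound 2 to compound 4 (1.61 log units; beyond the scatter) when set against 4-ethoxyphenyl, so the high reading is not tied to pyridin-3-yl alone. Among the four compounds, the low readings now come only with phenyl and 4-ethoxyphenyl at this carbon, while both pyridin-3-yl and propyl give high readings; the ring of compound 3 therefore goes against any simple split between rings and open chains. The step between compound 3 and compound 4 cannot be read because each compound gives a limit of the assay and not a number: the limit of > 1000 nM in this assay, at which 2 of the 4 values shown sit.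

As far as these compounds go, how far compound 3 and compound 4 actually lie apart stays open. So does whether a benzyl group, a pyridin-4-yl ring or a longer chain such as hexyl at this carbon would bring the number down.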